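The compounds below may be only part of what the source reports. "The series", "measured", "known", "first", "only" and "open" are said of these compounds alone.

Compound 2, with the structure `CC(C)C[C@H](N)c1cc(C(F)(F)F)ccc1N1CCN(C(=O)[C@H]2CS(=O)(=O)C[C@@H]2c2ccc(Cl)cc2)CC1`, sets the benchmark within this small set. In an assay on HEK293 cells for displacement of a labelled ligand from Melanocortin receptor 4 (Homo sapiens) (a higher number here means a weaker inhibitor, a lower number a stronger inhibitor), compound 2 gives 38 nM, the lowest number among the three measured compounds. Compound 1, `CC(C)C[C@H](N)c1cc(C(F)(F)F)ccc1N1CCN(C(=O)[C@H]2C[S+]([O-])C[C@@H]2c2ccc(Cl)cc2)CC1`, carries a sulfoxide where compound 2 carries a sulfone. In this assay compound 1 gives 120 nM, a weaker result lying beyond the scatter. Compound 3, `CC(C)[C@H](N)c1cccc(F)c1N1CCN(C(=O)[C@H]2CCO[C@@H]2c2ccc(Cl)cc2)CC1`, a more distant relative with a different ring and a different amine-bearing side chain, gives 1100 nM in this assay, the weakest value of the three.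

Compound 4, `CN[C@H](C)C(=O)N[C@@H](CC(C)C)c1cc(C(F)(F)F)ccc1N1CCN(C(=O)[C@H]2CS(=O)(=O)C[C@@H]2c2ccc(Cl)cc2)CC1`, is the compound that remains to be measured. It is built directly from compound 2 by a single change: (1-(methylamino)ethyl)carbonyl in place of hydrogen on an amine nitrogen. Among the compounds with values here, no measured pair in this set shows what this acylation of the primary amine does, so the expectation rests on the starting point alone. Because compound 2 already stands at 38 nM, the step is expected to be modest in either direction, most likely within the scatter, giving an expected step of a 1.1-fold higher number from compound 2 to compound 4 (0.02 log units; within the scatter). Compound 4 is therefore estimated at 40 nM in this assay, with a plausible range from 10 nM to 160 nM.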

Compound 4, inhibition constant: 100 nM
The estimate for compound 4 lay 2.5-fold (0.40 log units) below the measured number; low and high end bracket the measured number.
By their numbers in this assay, from the lowest: compound 2; then compounds 4 and 1 (each within the scatter of the next); then compound 3.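

In this assay, within the data shown here, the change gives a 2.6-fold higher number from compound 2 to compound 4 (0.42 log units; beyond the scatter), the first reading of what happens at this amine nitrogen. The step lies beyond the scatter but is modest: with (1-(methylamino)ethyl)carbonyl in place of hydrogen, compound 4 still gives 100 nM, so in this series the primary amine of compound 2 can be acylated with this group at only a limited cost. Nothing available explains why the number rises with this change.

The compounds shown leave open whether the rise follows from acylating the nitrogen as such or from this particular group, a question that a plain acetyl group, an aminoacetyl group or a single methyl on the same nitrogen would address. They also leave open whether the opposite configuration at the stereocentre of the entering group gives a different number, and whether the same change on the sulfoxide of compound 1 produces a step of similar size.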